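The source may hold more compounds than are shown below. What is called first, only, known or untested is meant among the compounds shown, and "the series" means these compounds.

Measured compounds:
- compound 1, `Nc1scc(CN2CCN(c3ccc(F)cc3Cl)CC2)c1C(=O)c1ccc(Cl)cc1`: 0%
- compound 2, `Nc1scc(CN2CCN(c3cccc(F)c3)CC2)c1C(=O)c1ccc(Cl)cc1`: 4%
- compound 3, `Nc1scc(CN2CCN(c3ccccc3F)CC2)c1C(=O)c1ccc(Cl)cc1`: 0%

All three share one core and differ only in the aryl group on the amine nitrogen in the ring. In an assay on CHO cells for displacement of a labelled ligand from adenosine receptor A3 (Homo sapiens), read by scintillation counting, with a stated time of 120 min, tested at 10 uM (on this read-out lower numbers stand for less inhibition and higher numbers for more inhibition at the one concentration tested (going by the name of the read-out)), compound 3 gives 0%, level with compound 1 and together with it the lowest of the three numbers; the step of no change at the digits printed from compound 1 to compound 3 (within the scatter) and the step of a number 4 percentage points lower from compound 2 to compound 3 (within the scatter) both lie within the scatter, as does a number 4 percentage points higher from compound 1 to compound 2 (within the scatter). None of the aryl changes seen so far has moved the read-out beyond the scatter.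

Compound 4, `Nc1scc(CN2CCN(c3ccc(F)cc3F)CC2)c1C(=O)c1ccc(Cl)cc1`, is not yet measured. Against compound 3 it carries fluoro in place of hydrogen on an aromatic carbon, which read one bond further out is 2-fluorophenyl to 2,4-difluorophenyl. For the measured compounds named here, the steps that bear on this are the aryl swaps among compounds 1, 2 and 3, all of them flat, so the step of a number 2 percentage points higher from compound 3 to compound 4 (within the scatter) is expected to be none beyond the scatter. For compound 4 in this assay the estimate is 2%, with a range from -6% to 12%.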

Compound 4, a percentage reported as inhibition, at one concentration (the size of the read-out at that concentration, not a potency): 0%
Estimate against measurement, compound 4: 2 percentage points above; the measured number falls inside the stated range.
By their numbers in this assay, from the lowest: compounds 1, 3, 4 and 2 (each within the scatter of the next).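

In this assay, fluoro in place of hydrogen on the aromatic carbon para to a large group and meta to the existing fluoro group gives no change at the digits printed from compound 3 to compound 4 (within the scatter), the first single-atom addition read on this aryl group. Fluoro in place of chloro on an aromatic carbon gives no change at the digits printed from compound 1 to compound 4 (within the scatter), and 2,4-difluorophenyl in place of 3-fluorophenyl gives a number 4 percentage points lower from compound 2 to compound 4 (within the scatter), so these halogen changes also leave the read-out flat. No measurement available here accounts for this flatness.

All four compounds lie within the scatter of one another, so no aryl change here separates them at the single concentration tested. As far as these compounds go, it remains open whether a group other than a halogen on this aryl ring, such as methoxy, a carboxylic acid or an amine, would move the read-out beyond the scatter.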